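The source may report more compounds than this note shows. Statements on the series, on what has been measured and on what is new or still open speak of the compounds shown alone.

The series shares one core and varies only the group on the carbonyl carbon of the amide arm. Compound 1 `CN1[C@@H]2c3[nH]c4ccccc4c3C[C@H]1[C@H](C#N)N1[C@@H](CNC(=O)c3ccc(Cl)cc3)c3[nH]c4ccccc4c3C[C@@H]21` carries a 4-chlorophenyl there and in a functional assay on HT-29 cells (Homo sapiens) for cytotoxicity, read by MTT assay, with a stated time of 72 h (a higher number here means a weaker inhibitor, a lower number a stronger inhibitor), compound 1 gives 130 nM. Compound 2 `CN1[C@@H]2c3[nH]c4ccccc4c3C[C@H]1[C@H](C#N)N1[C@@H](CNC(=O)c3cc4ccccc4[nH]3)c3[nH]c4ccccc4c3C[C@@H]21` replaces that ring with a 1H-indol-2-yl, and compound 2 gives 1220 nM, a step of a 9.4-fold higher number from compound 1 to compound 2 (0.97 log units; beyond the scatter). Compound 3 `CN1[C@@H]2c3[nH]c4ccccc4c3C[C@H]1[C@H](C#N)N1[C@@H](CNC(=O)/C=C/c3cccc(C(F)(F)F)c3)c3[nH]c4ccccc4c3C[C@@H]21` carries a 2-(3-(trifluoromethyl)phenyl)ethenyl on the carbonyl carbon, and compound 3 gives 5060 nM, which is the highest number of the three; the steps to it are a 39-fold higher number from compound 1 to compound 3 (1.59 log units; beyond the scatter) and a 4.1-fold higher number from compound 2 to compound 3 (0.62 log units; beyond the scatter).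

Compound 4 `COc1ccc(/C=C/C(=O)NC[C@H]2c3[nH]c4ccccc4c3C[C@H]3[C@H]4c5[nH]c6ccccc6c5C[C@@H]([C@H](C#N)N23)N4C)cc1` keeps the ethenyl arm and alters only its aryl end: 4-methoxyphenyl in place of 3-(trifluoromethyl)phenyl on a double-bonded chain carbon bound to a double-bonded chain carbon. None of the three measured steps bears directly on this change, since each of them exchanges the entire group on the carbonyl carbon, and the two steps that introduce the ethenyl arm are the largest seen. With the arm retained, the step from compound 3 to compound 4 in this assay is expected to be small, and compound 4 is estimated at 4000 nM, with a range from 1500 nM to 12000 nM, corresponding to an expected step of a 1.3-fold lower number from compound 3 to compound 4 (0.10 log units; within the scatter).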

Compound 4, half-maximal inhibitory concentration: 3060 nM
Estimate against measurement, compound 4: 1.3-fold (0.12 log units) above, and the stated range covers the measured number.
By their numbers in this assay, from the lowest: compound 1; then compound 2; then compounds 4 and 3 (each within the scatter of the next).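

Within this assay, this is the first change that leaves the ethenyl arm in place and alters only its aryl end, and the number barely moves: a 1.7-fold lower number from compound 3 to compound 4 (0.22 log units; within the scatter). The 3-(trifluoromethyl)phenyl and 4-methoxyphenyl ends therefore cannot be told apart here, although the entering group carries a hydrogen-bond acceptor and the leaving group none. The ethenyl arm with its new end still lies well away from the other two groups on the carbonyl carbon, with a 2.5-fold higher number from compound 2 to compound 4 (0.40 log units; beyond the scatter) and a 24-fold higher number from compound 1 to compound 4 (1.37 log units; beyond the scatter), so the large distance from the 4-chlorophenyl amide is not tied to a single aryl end, and no measurement at hand accounts for any of these differences.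

As far as these compounds go, the two aryl ends differ in both the substituent and its place on the ring, so neither factor can be judged alone, and a 3-methoxyphenyl or an unsubstituted phenyl on the arm remains open. From the compounds shown here alone, whether the loss follows the ethenyl link or the aryl group attached to it also remains open, a question that a 2-(4-chlorophenyl)ethenyl group or a saturated two-carbon chain would address.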